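The source may hold more compounds than are shown below. What is called first, only, known or untested is meant among the compounds shown, and "the series" means these compounds.

In a functional assay on HT-29 cells (Homo sapiens) for cytotoxicity, read by MTT assay, with a stated time of 72 h (a higher number here means a weaker inhibitor, a lower number a stronger inhibitor), compound 1 `CN(C)CCn1cnnc1-c1cc(Oc2ccc(NC(=O)N/N=C/c3cccc(Br)c3)cc2F)ccn1` gives 380 nM. For the measured compounds named here, compound 2 `CN(C)CCn1cnnc1-c1cc(Oc2ccc(NC(=O)N/N=C/c3ccc(O)c(O)c3)cc2F)ccn1` gives 1890 nM in this assay, the higher of the two numbers recorded; its only neighbour is compound 1, and the step of a 5.0-fold higher number from compound 1 to compound 2 (0.70 log units; beyond the scatter) is the one comparison available. Compound 3 `CN(C)CCn1cnnc1-c1cc(Oc2ccc(NC(=O)N/N=C/c3ccccc3O[N+](=O)[O-])cc2F)ccn1` has not yet been measured in this assay. The change from compound 2 is 2-(nitrooxy)phenyl in place of 3,4-dihydroxyphenyl on a carbon with a double bond to nitrogen. Going by the values given here, the only measured step bearing on this is a 5.0-fold higher number from compound 1 to compound 2 (0.70 log units; beyond the scatter), which installed the 3,4-dihydroxyphenyl that compound 3 now loses; the entering 2-(nitrooxy)phenyl, with 0 hydrogen-bond donors, moves away from that group rather than back to 3-bromophenyl, so a partial return toward the number of compound 1 is expected rather than a full one. Compound 3 is thus expected to give 650 nM in this assay, with a likely range from 250 nM to 1700 nM. That estimate amounts to an expected 2.9-fold lower number from compound 2 to compound 3 (0.46 log units; beyond the scatter).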

Compound 3, half-maximal inhibitory concentration: 950 nM
Beside the measured number, compound 3's estimate is 1.5-fold (0.16 log units) below it; measured number inside the range.
By their numbers in this assay, from the lowest: compound 1; then compounds 3 and 2 (each within the scatter of the next).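

In this assay, the exchange of 3,4-dihydroxyphenyl for 2-(nitrooxy)phenyl gives a 2.0-fold lower number from compound 2 to compound 3 (0.30 log units; within the scatter), so at this carbon with a double bond to nitrogen, losing the hydrogen-bond donors of the 3,4-dihydroxyphenyl leaves no difference that can be read. Set against the bromo compound, the same group gives a 2.5-fold higher number from compound 1 to compound 3 (0.40 log units; beyond the scatter), which leaves compound 1, with its 3-bromophenyl, as the most potent of the three, with steps to both others beyond the scatter. Nothing measured here gives a reason for these numbers.

On these data alone, whether the bromine itself sets compound 1 apart stays open, as the numbers for an unsubstituted phenyl, a 3-chlorophenyl or a 3-carboxyphenyl are unknown here. Also open, as far as these compounds go, is whether 3-(nitrooxy)phenyl would read like 2-(nitrooxy)phenyl or like 3-bromophenyl.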